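Adding a Second Chloro Group on Two Related Cores

A few compounds are considered here, and "the series" means these few. Any claim that something is new, unique, unknown or untested is made for them only; others in the source may bear on it.

Compound 1 `ClCc1ccc(Cn2cnc3c(Cl)ncnc32)cc1` and compound 2 `ClCc1cccc(Cn2cnc3ncnc(Cl)c32)c1` are built from the same atoms joined differently; the difference between the two cores is not broken down here. In a functional assay on UO-31 cells (Homo sapiens) for cytotoxicity, read by sulforhodamine B assay, with a stated time of 48 h (on this read-out lower numbers stand for stronger inhibition of growth and higher numbers for weaker inhibition of growth), compound 1 gives 4570 nM, and compound 2 gives 3090 nM, which lies within the scatter of compound 1. Compound 3 `ClCc1ccc(Cn2cnc3c(Cl)nc(Cl)nc32)cc1` differs from compound 1 by chloro in place of hydrogen on an aromatic carbon, and in this assay compound 3 gives 35500 nM, so a 7.8-fold higher number from compound 1 to compound 3 (0.89 log units; beyond the scatter). Compound 4 `ClCc1cccc(Cn2cnc3nc(Cl)nc(Cl)c32)c1`, not yet measured, differs from compound 2 by chloro in place of hydrogen on an aromatic carbon, the same change at the same place, made twice across these compounds. Going by the values given here, the step is expected to be a 7.8-fold higher number from compound 2 to compound 4 (0.89 log units; beyond the scatter), because a 7.8-fold higher number from compound 1 to compound 3 (0.89 log units; beyond the scatter) is the only measured example of this change. Compound 4 is therefore estimated at 24000 nM, between 8000 nM and 70000 nM.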

Compound 4, concentration for total growth inhibition: 35500 nM
Estimate against measurement, compound 4: 1.5-fold (0.17 log units) below; measured number inside the range.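

On the core of compound 2, chloro in place of hydrogen between two ring nitrogen atoms gives an 11-fold higher number from compound 2 to compound 4 (1.06 log units; beyond the scatter) in this assay. The step therefore carries over from one core to the other, in direction and in size: the same change on two cores in this assay, a 7.8-fold higher number (0.89 log units; beyond the scatter) from compound 1 to compound 3 and an 11-fold higher number (1.06 log units; beyond the scatter) from compound 2 to compound 4, 1.5-fold (0.17 log units) apart, within the scatter of two such steps. Going by these compounds alone, this rests on only two pairs of compounds in a single assay, so it does not show that the change would behave alike on any further core, nor does it explain why the number rises.

The compounds shown leave open whether a different group at that place, such as an amine or a methoxy group, would move the number as far as chloro does.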